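Furan for thiophene on the saturated ring carbon

The source may hold more compounds than are shown below. What is called first, only, known or untested is meant among the compounds shown, and "the series" means these compounds.

Measured compounds:
compound 1 `CCOC(=O)C1=C(C)N/C(=N\C#N)NC1c1ccoc1` gives 28% in an assay on cells for displacement of a labelled ligand from adenosine receptor A1 (Homo sapiens), with a stated time of 60 min, tested at 1 uM; a lower number here means less inhibition, a higher number more inhibition at the concentration tested (going by the name of the read-out).
compound 2 `CC1=C(C(=O)OC(C)C)C(c2ccsc2)N/C(=N/C#N)N1` gives 11% in this assay.

Compound 2 stands lowest of the two numbers in this assay; compound 1 lies beyond the scatter above it. Compound 3 `CC1=C(C(=O)OC(C)C)C(c2ccoc2)N/C(=N/C#N)N1` has not been measured. It differs from compound 2 in one place: furan-3-yl in place of thiophen-3-yl on a saturated ring carbon. For the measured compounds named here, no measured pair shows this change alone, so no step size is known. Compound 1 carries the furan too, which suggests a modest rise. The expected step is a number 9 percentage points higher from compound 2 to compound 3 (within the scatter). Compound 3 is estimated to give 20%, within the range 5% to 38%.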

Compound 3, a percentage reported as inhibition, at one concentration (the size of the read-out at that concentration, not a potency): 34%
The estimate for compound 3 lay 14 percentage points below the measured number, within the range that was stated.
By their numbers in this assay, from the lowest: compound 2; then compounds 1 and 3 (each within the scatter of the next).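

In this assay, furan-3-yl in place of thiophen-3-yl on the saturated ring carbon gives a number 23 percentage points higher from compound 2 to compound 3 (beyond the scatter), the first sign that this position responds to swapping the single ring hetero atom, sulfur for oxygen. With the furan-3-yl group kept, adding a methyl to the ester chain gives a number 6 percentage points higher from compound 1 to compound 3 (within the scatter), so this ester change shows no clear effect on the number. Nothing available explains the rise seen with the furan-3-yl group. From the compounds shown here alone, what a phenyl ring at this ring carbon, or a longer chain on the ester, would do remains open.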